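The source may hold more compounds than are shown below. What is called first, only, known or untested is meant among the compounds shown, and "the series" means these compounds.

Among the measured compounds shown here, compound 2 `CC(C)(C)CNCCS(=O)(=O)NC(=O)c1ccc(Nc2nc(NC3(c4ccc(Cl)cc4)CC3)nc(OCC(F)(F)F)n2)cc1` is, of the two compounds measured in an ADME assay on microsomes from liver (Homo sapiens) for metabolic stability, with a stated time of 10 min (a lower number here means that less of the compound is left, a higher number that more of the compound is left), the one with the top number, giving 89%; compound 1 `CC(C)C(=O)NCCS(=O)(=O)NC(=O)c1ccc(Nc2nc(NC3(c4ccc(Cl)cc4)CC3)nc(OCC(F)(F)F)n2)cc1` gives 86%, and the step of a number 3 percentage points higher from compound 1 to compound 2 (within the scatter) separates them. Compound 3 `O=C(NS(=O)(=O)CCNCc1ccccc1)c1ccc(Nc2nc(NC3(c4ccc(Cl)cc4)CC3)nc(OCC(F)(F)F)n2)cc1` differs from compound 2 by phenyl in place of tert-butyl on a saturated chain carbon bound to an amine nitrogen. For the measured compounds named here, the single measured step, that between compound 1 and compound 2, is the only one bearing on this change, and it was small; with so little to go on, no step beyond the scatter is expected in this assay. Compound 3 is therefore estimated at 82%, within 65% to 95%, an expected step of a number 7 percentage points lower from compound 2 to compound 3 (within the scatter).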

Compound 3, percent of the compound remaining: 99%
Estimate against measurement, compound 3: 17 percentage points below; the whole stated range lies below it.
By their numbers in this assay, from the lowest: compounds 1, 2 and 3 (each within the scatter of the next, the first and the last beyond it).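

Phenyl in place of tert-butyl on a saturated chain carbon bound to an amine nitrogen gives a number 10 percentage points higher from compound 2 to compound 3 (within the scatter) in this assay, so a six-membered aromatic ring at this place brings no loss that this read-out can detect. Benzyl in place of isopropylcarbonyl on the amine nitrogen gives a number 13 percentage points higher from compound 1 to compound 3 (beyond the scatter), and this modest step is the only one here to pass the scatter. No measured evidence accounts for either step.
The compounds shown leave open whether a pyridylmethyl group or a longer chain such as phenethyl on this nitrogen would keep the number where it stands.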